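The compounds below may be only part of what the source reports. "The series", "measured", "known", "first", "only" and "open" are said of these compounds alone.

Measured compounds:
compound 1, `CC[C@H]1OC(=O)[C@H](C)[C@@H](O[C@H]2C[C@@](C)(OC)[C@@H](OCCCNC(C)=O)[C@H](C)O2)[C@H](C)[C@@H](O[C@@H]2O[C@H](C)C[C@H](N(C)C)[C@H]2O)[C@](C)(O)C[C@@H](C)CN(C)[C@H](C)[C@@H](O)[C@]1(C)O`: 2.06
compound 2, `CCCCCCCC(=O)NCCCO[C@H]1[C@H](C)O[C@@H](O[C@H]2[C@H](C)[C@@H](O[C@@H]3O[C@H](C)C[C@H](N(C)C)[C@H]3O)[C@](C)(O)C[C@@H](C)CN(C)[C@H](C)[C@@H](O)[C@](C)(O)[C@@H](CC)OC(=O)[C@@H]2C)C[C@@]1(C)OC`: 4.1
compound 3, `CCCCCCCC(=O)NCCCO[C@H]1[C@H](C)O[C@@H](O[C@H]2[C@H](C)[C@@H](O[C@@H]3O[C@H](C)C[C@H](N(C)C)[C@H]3O)[C@](C)(OC)C[C@@H](C)C(=O)[C@H](C)[C@@H](O)[C@](C)(O)[C@@H](CC)OC(=O)[C@@H]2C)C[C@@]1(C)OC`: 6.02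

All three values come from a physicochemical assay for lipophilicity, read by HPLC, measured as chromatographic lipophilicity, at pH 7.4; a higher number here means a more lipophilic compound, a lower number a more polar compound. Compound 2 and compound 1 share one core and differ in one place only, (hydrogen in place of hexyl on a saturated chain carbon bound to a carbonyl carbon). That change gave a number 2.04 log units lower from compound 2 to compound 1 (beyond the scatter), a large step. Compound 3 is built on a different core from compound 2; the difference between the two cores is not broken down here, and its value in this assay stands as the highest of the three.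

Compound 4, `CC[C@H]1OC(=O)[C@H](C)[C@@H](O[C@H]2C[C@@](C)(OC)[C@@H](OCCCNC(C)=O)[C@H](C)O2)[C@H](C)[C@@H](O[C@@H]2O[C@H](C)C[C@H](N(C)C)[C@H]2O)[C@](C)(OC)C[C@@H](C)C(=O)[C@H](C)[C@@H](O)[C@]1(C)O`, has not yet been measured. It relates to compound 3 as compound 1 relates to compound 2: hydrogen in place of hexyl on a saturated chain carbon bound to a carbonyl carbon. The place of the change reads the same word for word in both pairs, so this is the same change made a second time, now on the core of compound 3.

For the measured compounds named here, the step is expected to repeat in size, resting on the one measured instance, a number 2.04 log units lower from compound 2 to compound 1 (beyond the scatter), and on the value of compound 3, 6.02. For compound 4 the expected step is a number 2.02 log units lower from compound 3 to compound 4 (beyond the scatter) in this assay. The expected value for compound 4 in this assay is therefore 4, with a range from 3.4 to 4.6.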

Compound 4, distribution coefficient: 3.08
For compound 4 the middle estimate is 0.92 log units above the measured one, outside the stated range (below it).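

In this assay, hydrogen in place of hexyl gives a number 2.94 log units lower from compound 3 to compound 4 (beyond the scatter) and so runs the same way as a number 2.04 log units lower from compound 2 to compound 1 (beyond the scatter) on the other core, with the step on the core of compound 3 the larger of the two. The direction and the large size of the step therefore carry from one core to the other in these two pairs, but its exact size does not, and one pair per core gives no rule for how far the step shifts with the core. No measurement shown accounts for the difference in size between the two cores.

Only hexyl and hydrogen are shown at this place, so it remains open whether a propyl chain would give a step of intermediate size, or how a chain ending in an amine or a carboxylic acid would read in this assay on either core. On these data alone, whether the step would keep its direction on a third core also remains open.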